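The source may report more compounds than this note shows. Statements on the series, on what has been measured and on what is new or still open speak of the compounds shown alone.

Of the compounds shown here, three built on one shared core have been tested in an assay (Rattus norvegicus) for inhibition of Fatty-acid amide hydrolase 1 (Homo sapiens); a lower number here means a stronger inhibitor, a higher number a weaker inhibitor. Compound 1 `O=C(CCCCCCc1ccccc1)c1ncc(-c2ccc([N+](=O)[O-])cc2)o1` gives 50 nM. Compound 2 `O=C(CCCCCCc1ccccc1)c1ncc(C(=O)N2CCOCC2)o1` gives 24 nM, and compound 3 `O=C(CCCCCCc1ccccc1)c1ncc(Cl)o1` gives 5 nM, the lowest of the three numbers. The moves a 10-fold lower number from compound 1 to compound 3 (1.00 log units; beyond the scatter) and a 4.8-fold lower number from compound 2 to compound 3 (0.68 log units; beyond the scatter) both end at the chloro compound, while a 2.1-fold lower number from compound 1 to compound 2 (0.32 log units; beyond the scatter) is the smaller move. Compound 4 `CSc1cnc(C(=O)CCCCCCc2ccccc2)o1` awaits measurement; the change is methylsulfanyl in place of chloro on an aromatic carbon. Going by the values given here, no measured step swaps chloro for another small group, so the two steps ending at compound 3 show only that the larger groups gave higher numbers. A small step toward a higher number, or none beyond the scatter, is expected, as a 1.8-fold higher number from compound 3 to compound 4 (0.26 log units; within the scatter). Compound 4 is estimated at 9 nM, within 3 nM to 30 nM.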

Compound 4, inhibition constant: 25 nM
Compound 4: middle estimate off by 2.8-fold (0.44 log units), on the low side; low and high end bracket the measured number.
By their numbers in this assay, from the lowest: compound 3; then compounds 2, 4 and 1 (each within the scatter of the next, the first and the last beyond it).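

In this assay methylsulfanyl in place of chloro gives a 5.0-fold higher number from compound 3 to compound 4 (0.70 log units; beyond the scatter) and so shows that this position, next to the ring oxygen, responds even when only a small group changes. Compound 4 also lands level with the two larger groups, with a 1.0-fold higher number from compound 2 to compound 4 (0.02 log units; within the scatter) and a 2.0-fold lower number from compound 1 to compound 4 (0.30 log units; within the scatter) as its steps, so among these compounds a small group does not guarantee a low number. Nothing shown here gives a reason for this loss. As far as these compounds go, whether hydrogen, fluoro, methoxy or an amine at this position would stay near compound 3 remains open.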